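The compounds below may be only part of what the source reports. "The series", "measured", "known", "first", "only" and "open" are said of these compounds alone.

Measured compounds:
- compound 1 `C[C@H](Oc1ccc(/C=C/C(=O)O)c(C2CC2)c1)c1c(Cl)ccc(F)c1Cl`, 3.6
- compound 2 `C[C@H](Oc1ccc2ncc(/C=C/C(=O)O)c(C3CC3)c2c1)c1c(Cl)ccc(N)c1Cl`, 2.8

In a physicochemical assay for lipophilicity, using the shake flask method (on this read-out lower numbers stand for lower lipophilicity and higher numbers for higher lipophilicity), compound 2 gives 2.8, the lowest of the two numbers. Its nearest neighbour is compound 1, whose value of 3.6 is higher by an amount beyond the scatter. Among the measured compounds shown here, the two compounds differ in several places at once, so no single step between them is defined; only their two values are known.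

Compound 3 `C[C@H](Oc1ccc2ncc(/C=C/C(=O)O)c(C3CC3)c2c1)c1c(Cl)ccnc1Cl` has not yet been measured in this assay. It differs from compound 2 in one place: a group of 8 heavy atoms (5 carbon, 1 nitrogen, 2 chlorine; one six-membered aromatic ring with 1 hetero atom) in place of a group of 9 heavy atoms (6 carbon, 1 nitrogen, 2 chlorine; one six-membered aromatic ring of carbon only), on a saturated chain carbon bound to an oxygen on an aromatic ring and a saturated chain carbon. For the measured compounds named here, no matched step of this kind exists among the measured compounds, so the size of the effect has to be judged from the change alone.

The expectation is for no step beyond the scatter, or at most a small downward one, from compound 2 to compound 3 in this assay, that is a number 0.10 log units lower from compound 2 to compound 3 (within the scatter). Compound 3 is therefore estimated at 2.7 in this assay, with a plausible range from 2 to 3.4.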

Compound 3, distribution coefficient: 2.3
Compound 3: the middle estimate sits 0.40 log units above what was measured, within the range that was stated.
By their numbers in this assay, from the lowest: compound 3; then compound 2; then compound 1.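

In this assay, replacing the group of 9 heavy atoms in compound 2 with 2,4-dichloropyridin-3-yl, on a saturated chain carbon bound to an oxygen on an aromatic ring and a saturated chain carbon, gives a number 0.50 log units lower from compound 2 to compound 3 (beyond the scatter). Among the compounds shown here, this is the first one-place step, and it shows that the read-out responds to the group carried at this position, which compound 1 and compound 2 could not show because they differ in several places at once. The step also combines two counted differences, since the entering group has a six-membered aromatic ring with 1 hetero atom and 0 hydrogen-bond donors, while the leaving group has a ring of carbon only and 1 hydrogen-bond donor; no measurement shown bears on what lies behind the step.

From the compounds shown here alone, how the step divides between these two differences remains open, and a dichlorophenyl group at this position, with neither an amine nor a ring nitrogen, would bear directly on that question. Also open, going by these compounds, is whether a step of similar size would appear on the core of compound 1, or with a methoxy group on the pyridine ring of the entering group.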